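From a Methylphenyl Ring to a Pentyl Chain

This account rests on a few compounds, and the source may have more. Where it says the series, first, only, none or still open, it means among the compounds named here.

Compound 1 `Cc1ccc(CNC(=O)n2c(N)nc3ccccc32)cc1` and compound 2 `Cc1cccc(CNC(=O)n2c(N)nc3ccccc32)c1` share one core and differ only in where the methyl sits on the ring. Among the measured compounds shown here, in an assay on HEK293 cells for inhibition of acid ceramidase (Homo sapiens), read by fluorescence, with stated times of 30 min and 1 h (a lower number here means a stronger inhibitor, a higher number a weaker inhibitor), compound 1 gives 7 nM, and compound 2 gives 8.5 nM, the highest of the two numbers so far; the step of a 1.2-fold higher number from compound 1 to compound 2 (0.08 log units; within the scatter) lies within the scatter. Compound 3 `CCCCCCNC(=O)n1c(N)nc2ccccc21` differs from compound 2 by pentyl in place of 3-methylphenyl on a saturated chain carbon bound to an amide-type nitrogen. For the measured compounds named here, the one measured step only shifted a methyl on a ring, so no measured step speaks to swapping the ring for a chain. A modest rise is expected, a 1.8-fold higher number from compound 2 to compound 3 (0.25 log units; within the scatter). Compound 3 is therefore estimated at 15 nM, within a range from 4 nM to 60 nM.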

Compound 3, half-maximal inhibitory concentration: 2.4 nM
The estimate for compound 3 lay 6.3-fold (0.80 log units) above the measured number; measured number below the stated range.
By their numbers in this assay, from the lowest: compound 3; then compounds 1 and 2 (each within the scatter of the next).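

At this position, on a saturated chain carbon bound to an amide-type nitrogen, the ring is not required for a low number in this assay: pentyl in place of 3-methylphenyl gives a modest drop (a 3.5-fold lower number from compound 2 to compound 3 (0.55 log units; beyond the scatter)), and pentyl in place of 4-methylphenyl gives another (a 2.9-fold lower number from compound 1 to compound 3 (0.46 log units; beyond the scatter)). Unlike moving the methyl on the ring, both changes go beyond the scatter. No measurement shown here explains this gain.

From the compounds shown here alone, it remains open whether a longer chain, a shorter chain or a branched chain would keep this low number. Going by these compounds, it is equally open whether an amine or a carboxylic acid could stand in place of pentyl.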